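Urea-linked pyrazoles on lung cancer cells: phenol versus methyl ether

The source may report more compounds than this note shows. Statements on the series, on what has been measured and on what is new or still open speak of the compounds shown alone.

Measured so far:
compound 1, `O=C(Nc1cccc(-n2cc(-c3ccncc3)c(-c3ccc(Cl)c(O)c3)n2)c1)Nc1cccc(C(F)(F)F)c1`: > 32500 nM
compound 2, `COc1cc(-c2nn(-c3cccc(NC(=O)Nc4ccc(Cl)c(Cl)c4)c3)cc2-c2ccncc2)ccc1Cl`: > 50000 nM

Both compounds were tested in a functional assay on NCI-H460 cells (Homo sapiens) for inhibition, read by sulforhodamine B assay, with a stated time of 48 h; on this read-out lower numbers stand for higher toxicity in this test and higher numbers for lower toxicity in this test. Compound 1, `O=C(Nc1cccc(-n2cc(-c3ccncc3)c(-c3ccc(Cl)c(O)c3)n2)c1)Nc1cccc(C(F)(F)F)c1`, gives > 32500 nM, and this is a limit of the test rather than a number, as noted in the limit of > 32500 nM in this assay, at which 1 of the 2 values shown sits. Compound 2, `COc1cc(-c2nn(-c3cccc(NC(=O)Nc4ccc(Cl)c(Cl)c4)c3)cc2-c2ccncc2)ccc1Cl`, gives > 50000 nM in this assay, again only a limit, recorded in the limit of > 50000 nM in this assay, at which 1 of the 2 values shown sits. So compound 2 stands at a limit, and the other value shown is a limit too; neither compound gave a measured number in this test.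

Compound 3, `O=C(Nc1cccc(-n2cc(-c3ccncc3)c(-c3ccc(Cl)c(O)c3)n2)c1)Nc1ccc(Cl)c(Cl)c1`, has not yet been measured. It differs from compound 2 by hydrogen in place of methyl on an oxygen on an aromatic ring; in words, hydrogen in place of methyl on an oxygen on an aromatic ring. Compound 1 already carries that same hydroxy group and sits at a limit, so the change is not expected to move the read-out beyond the scatter, and the step from compound 2 to compound 3 is expected to be an at least 1.1-fold lower number from compound 2 to compound 3 (0.04 log units; that floor lies within the scatter). Compound 3 is therefore estimated at 45000 nM, within a range from 15000 nM to 120000 nM, most likely reported again only as a limit.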

Compound 3, concentration lethal to 50% of the cells: 24200 nM
Compound 3: the middle estimate sits 1.9-fold (0.27 log units) above what was measured; measured number inside the range.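

In this assay, among the compounds shown here, compound 3 is the first compound here to give a real number instead of a limit, which shows that this position can affect the read-out. Hydrogen in place of methyl on the oxygen, turning methoxy into hydroxy, gives an at least 2.0-fold lower number from compound 2 to compound 3 (0.31 log units; beyond the scatter), so the phenol is the more toxic of this pair in this test, and this step is only a minimum. The value of compound 2 is a limit and not a number: the limit of > 50000 nM in this assay, at which 1 of the 3 values shown sits. At the other end of the molecule, with the hydroxy group held fixed, 3,4-dichlorophenyl in place of 3-(trifluoromethyl)phenyl on an amide-type nitrogen gives an at least 1.3-fold lower number from compound 1 to compound 3 (0.12 log units; that floor lies within the scatter), a minimum that does not clear the scatter, so this swap is not shown to matter.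

The compounds shown leave open whether the lower number comes from the hydroxy group itself or simply from losing the methyl, a question that an amino group or an ethoxy group in the same place would help to settle. They also leave open how large the true gaps are, since only compound 3 has a real number.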